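A few compounds are considered here, and "the series" means these few. Any claim that something is new, unique, unknown or untested is made for them only; others in the source may bear on it.

Working notes on the series.

Three compounds are measured in an ADME assay on HepG2 cells (Homo sapiens) for cytotoxicity, read by luminescence, CellTiter-Glo and ATP content, with a stated time of 72 h; on this read-out lower numbers stand for an effect already at smaller amounts and higher numbers for an effect only at larger amounts of compound. Compound 1 `COc1cccc(CNCCCNc2ccnc3cc(-c4ccccc4)ccc23)c1O` gives 3210 nM. Compound 2 `COc1ccc(F)cc1CNCCCNc1ccnc2cc(CCc3ccccc3)ccc12` gives 4240 nM. Compound 3 `COc1cccc(CNCCCNc2ccnc3cc(CCc4ccccc4)ccc23)c1O` gives 6800 nM. The values of compound 2 and compound 1 lie within the scatter of one another, as do those of compound 2 and compound 3.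

The cores of compound 3 and compound 2 differ by 5-fluoro-2-methoxyphenyl in place of 2-hydroxy-3-methoxyphenyl on a saturated chain carbon bound to an amine nitrogen; read in the other direction, the step of a 1.6-fold higher number from compound 2 to compound 3 (0.21 log units; within the scatter) stays within the scatter.

Compound 4 `COc1ccc(F)cc1CNCCCNc1ccnc2cc(-c3ccccc3)ccc12` is not yet measured. It relates to compound 2 through (phenyl in place of phenethyl on an aromatic carbon). The same change, (phenyl in place of phenethyl on an aromatic carbon), links the measured pair, where it made a modest step, a 2.1-fold lower number from compound 3 to compound 1 (0.33 log units; beyond the scatter), beyond the scatter. The place of the change is the same in both pairs, and the two cores differ only as told above.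

The expectation for compound 4 in this assay is a step of about a 2.0-fold lower number from compound 2 to compound 4 (0.31 log units; beyond the scatter), beside the earlier one, resting on the single measured occurrence of the change from compound 3 to compound 1 and on the value of compound 2, 4240 nM.

Compound 4 is estimated at 2100 nM, with a range expected from 1100 nM to 4200 nM.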

Compound 4, half-maximal effective concentration: 2960 nM
Estimate against measurement, compound 4: 1.4-fold (0.15 log units) below; the range from low to high includes it.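

In this assay, phenyl in place of phenethyl on an aromatic carbon gives a 1.4-fold lower number from compound 2 to compound 4 (0.16 log units; within the scatter), so the step on this core stays within the scatter, although the measured step on the other core lay beyond it; the two steps themselves cannot be told apart: the same change on two cores in this assay, a 2.1-fold lower number (0.33 log units; beyond the scatter) from compound 3 to compound 1 and a 1.4-fold lower number (0.16 log units; within the scatter) from compound 2 to compound 4, 1.5-fold (0.17 log units) apart, within the scatter of two such steps
The exchange of the aryl group on the saturated chain carbon, 5-fluoro-2-methoxyphenyl in place of 2-hydroxy-3-methoxyphenyl, gives a 1.1-fold lower number from compound 1 to compound 4 (0.04 log units; within the scatter), and read in the opposite direction it also agrees across the two cores: the same change on two cores in this assay, a 1.6-fold higher number (0.21 log units; within the scatter) from compound 2 to compound 3 and a 1.1-fold higher number (0.04 log units; within the scatter) from compound 4 to compound 1, 1.5-fold (0.17 log units) apart, within the scatter of two such steps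
This shows that the four compounds are compatible with carrying the change from one core to the other, but it does not establish a real effect of the change on the core of compound 2, and two cores make no general rule for the series.

The compounds shown leave open how a benzyl or a pyridyl group on the same aromatic carbon would read in this assay. As far as these compounds go, the effect of a longer chain linking the two amine nitrogens also remains open.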